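A few compounds are considered here, and "the series" means these few. Any claim that something is new, unique, unknown or untested is made for them only; others in the source may bear on it.

The study concerns a small set of compounds built on one shared core and tested in an assay for inhibition of Polyunsaturated fatty acid lipoxygenase ALOX15 (Homo sapiens), with a stated time of 10 min; on this read-out higher numbers stand for weaker inhibition and lower numbers for stronger inhibition. Compound 1 has the structure `Nc1[nH]c(C(=O)c2ccccc2)c(-c2cccc3ccccc23)c1C(=O)c1ccc(Cl)c(Cl)c1`. In this assay compound 1 gives > 100000 nM, which is a limit of the assay and not a number. Compound 2, with the structure `Nc1[nH]c(C(=O)c2ccccc2)c(-c2ccncc2)c1C(=O)c1cccc(Cl)c1`, belongs to the same series. In this assay compound 2 gives > 100000 nM, again a limit rather than a number. Where compound 1 stands is thus told only by the evidence that both values reach the same limit: the limit of > 100000 nM in this assay, at which 2 of the 2 values shown sit. For the measured compounds named here, no step between measured compounds is available, so how this assay answers a single structural change is not known from these data. Compound 3, with the structure `Nc1[nH]c(C(=O)c2ccccc2)c(-c2ccc(Cl)cc2Cl)c1C(=O)c1ccc(Cl)c(Cl)c1`, remains to be measured. It differs from compound 1 in one place: 2,4-dichlorophenyl in place of naphthalen-1-yl on an aromatic carbon. In this assay the expected step of a number no higher from compound 1 to compound 3 (the limit leaves the size open) is none beyond the usual scatter, because the limit of > 100000 nM in this assay, at which 2 of the 2 values shown sit, shows compound 1 already at the limit. Compound 3 is therefore expected to give 100000 nM, estimated to lie between 30000 nM and 300000 nM, most likely again reported only as a limit.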

Compound 3, half-maximal inhibitory concentration: 12800 nM
The estimate for compound 3 lay 7.8-fold (0.89 log units) above the measured number, and the stated range ends above it.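

In this assay, putting 2,4-dichlorophenyl in place of naphthalen-1-yl on the aromatic carbon gives an at least 7.8-fold lower number from compound 1 to compound 3 (0.89 log units; beyond the scatter), the only step shown and one that lies beyond the usual scatter. Compound 1 gives > 100000 nM, which is a limit of the assay and not a number, so the step has a known minimum but no known full size. The group on this carbon of the five-membered ring can therefore separate compounds on the shared core and bring one to a measurable number, although most of the series still stands at the limit: the limit of > 100000 nM in this assay, at which 2 of the 3 values shown sit.

The data do not tell whether the change in this assay follows from the loss of the second aromatic ring or from the two chlorine atoms, and phenyl, 2-chlorophenyl and 4-chlorophenyl at this position would be needed to separate those parts. Also open, going by these compounds, is how this position would answer a carboxylic acid or an amine on the ring, and whether the same gain would hold with other groups on the carbonyl in place of 3,4-dichlorophenyl.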